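The source may hold more compounds than are shown below. What is called first, only, known or untested is meant among the compounds shown, and "the series" means these compounds.

Measured so far:
compound 1 `CCNC(=O)c1noc(-c2cc(C(C)C)c(O)cc2O)c1-c1cc(CNC(C)=O)no1` — a functional assay on A2780 cells (Homo sapiens) for inhibition; on this read-out lower numbers stand for stronger inhibition and higher numbers for weaker inhibition: "not determined" (no result reported)
compound 2 `CCNC(=O)c1noc(-c2cc(C(C)C)c(O)cc2O)c1-c1cc(CN(CC)CC)no1` — this assay: 78 nM
compound 3 `CCCN(CCC)Cc1cc(-c2c(C(=O)NCC)noc2-c2cc(C(C)C)c(O)cc2O)on1` — this assay: "not determined" (no result reported)

Among the measured compounds shown here, compound 1 stands without a number in this assay; the only number in the set belongs to compound 2. For the measured compounds named here, no step between two measured compounds exists, so nothing tells how the group on the aromatic carbon of the shared core moves the read-out. The step from compound 1 to compound 4 `CCNC(=O)c1noc(-c2cc(C(C)C)c(O)cc2O)c1-c1ccn(C(C)C)n1` is 1-isopropyl-1H-pyrazol-3-yl in place of 3-(acetamidomethyl)-1,2-oxazol-5-yl on an aromatic carbon. Going by the values given here, with no measured step to lean on, no direction is assumed; a shift in either direction within the scatter, or somewhat beyond it, is plausible, and compound 2 with 78 nM serves as the only anchor. Compound 4 is expected near 120 nM, with a range of 25 nM to 600 nM.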

Compound 4, half-maximal inhibitory concentration: 45 nM
The estimate for compound 4 lay 2.7-fold (0.43 log units) above the measured number; the range from low to high includes it.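

In this assay compound 1 has no single number, so no new step can be read between compound 1 and compound 4. The compounds shown leave open how the group on the aromatic carbon of the shared core moves the read-out. No measured evidence bears on this result.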